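This account rests on a few compounds, and the source may have more. Where it says the series, first, only, none or still open, it means among the compounds named here.

In a functional assay on HeLa cells (Homo sapiens) for cytotoxicity, read by MTT assay, with a stated time of 48 h (on this read-out lower numbers stand for stronger inhibition and higher numbers for weaker inhibition), compound 3 `O=C(O)CN1C(=O)/C(=C/c2nc3cc(F)ccc3n2Cc2ccccc2F)SC1=S` gives > 50000 nM, which is a limit and not a number, so its place is known only as the limit of > 50000 nM in this assay, at which 1 of the 3 values shown sits. The change to compound 4 `COc1ccc2c(c1)nc(/C=C1\SC(=S)N(CC(=O)O)C1=O)n2Cc1ccccc1F` is methoxy in place of fluoro on an aromatic carbon. With chloro on that carbon, compound 2 `O=C(O)CN1C(=O)/C(=C/c2nc3cc(Cl)ccc3n2Cc2ccccc2F)SC1=S` gives 9520 nM. Within the data shown here, the one measured step there is an at least 5.2-fold higher number from compound 2 to compound 3 (0.72 log units; beyond the scatter), so this carbon can move the number beyond the scatter. Compound 1 `COc1ccc2c(c1)nc(/C=C1\SC(=S)N(CC(=O)O)C1=O)n2Cc1ccc(C)cc1` carries the same methoxy, differs elsewhere, and gives 1820 nM. On that value of compound 1 1820 nM, a clear move to lower numbers is expected in this assay, with an estimated step of an at least 7.1-fold lower number from compound 3 to compound 4 (0.85 log units; beyond the scatter). For compound 4 the estimate is 7000 nM, with an expected range of 1800 nM to 30000 nM.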

Compound 4, half-maximal inhibitory concentration: 22500 nM
Estimate against measurement, compound 4: 3.2-fold (0.51 log units) below; the measured number falls inside the stated range.
By their numbers in this assay, from the lowest: compound 1; then compound 2; then compound 4. At a limit, above all of these: compound 3.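

Compound 3 stands at a limit and not a number: the limit of > 50000 nM in this assay, at which 1 of the 4 values shown sits.

On this carbon, methoxy in place of fluoro gives an at least 2.2-fold lower number from compound 3 to compound 4 (0.34 log units; beyond the scatter), and methoxy in place of chloro gives a 2.4-fold higher number from compound 2 to compound 4 (0.37 log units; beyond the scatter), so with 2-fluorophenyl held, the order runs chloro, then methoxy, then fluoro at its limit. Away from this carbon, with methoxy held, 2-fluorophenyl in place of 4-methylphenyl gives a 12-fold higher number from compound 1 to compound 4 (1.09 log units; beyond the scatter), so the methoxy group alone does not set the number.

Open, on these data alone, is how an amine or a hydroxyl on this carbon would compare with chloro. Also open, as far as these compounds go, is whether 4-methylphenyl moves the number the same way with chloro on this carbon.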